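From an ester chain to cyclopentyl

The compounds below may be only part of what the source reports. "The series", "measured", "known", "first", "only" and "open" are said of these compounds alone.

Measured in a functional assay (strain AB) with Danio rerio as the target, read by microscopy, with a stated time of 1 h; a lower number here means that less compound is needed, a higher number that more compound is needed for the effect:
- compound 1 `CC(C)(C)OC(=O)CCCCC[N+]1(C)CCc2c(sc(NC(=O)Nc3ccc(Cl)cc3)c2C(N)=O)C1`: 110 nM
- compound 2 `CCN1CCc2c(sc(NC(=O)Nc3ccc(Cl)cc3)c2C(=O)OC)C1`: > 25000 nM (a limit, not a number)

In this assay, within the data shown here, compound 1 gives 110 nM, the only true number available so far. Compound 2 reaches only a limit of the assay, > 25000 nM.

The next compound to be tested is compound 3 `C[N+]1(CC2CCCC2)CCc2c(sc(NC(=O)Nc3ccc(Cl)cc3)c2C(N)=O)C1`. It keeps the core of compound 1 and differs in one place: cyclopentyl in place of 4-(tert-butoxycarbonyl)butyl on a saturated chain carbon bound to an amine nitrogen in a ring.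

Among the measured compounds shown here, no measured pair isolates this change, so the expectation is a judgement that starts from compound 1 at 110 nM. Losing the whole 4-(tert-butoxycarbonyl)butyl group is expected to mean that more compound is needed in this assay, by a margin beyond the usual scatter. The expected size of the change is a 5.5-fold higher number from compound 1 to compound 3 (0.74 log units; beyond the scatter). For compound 3 the estimated half-maximal effective concentration is 600 nM, with an expected range from 120 nM to 4000 nM.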

Compound 3, half-maximal effective concentration: 200 nM
Beside the measured number, compound 3's estimate is 3.0-fold (0.48 log units) above it; low and high end bracket the measured number.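

In this assay, the change at this place, on a saturated chain carbon bound to an amine nitrogen in a ring, gives a 1.8-fold higher number from compound 1 to compound 3 (0.26 log units; within the scatter). The 4-(tert-butoxycarbonyl)butyl group, with its ester and open chain, can therefore give way to cyclopentyl, a compact ring of carbon only, without a change beyond the usual scatter, so for this pair the ester is not required to keep the number in this range. Compound 2 gives only a limit of the assay and differs from the other two compounds in more than one place, so it cannot be read as part of this comparison: the limit of > 25000 nM in this assay, at which 1 of the 3 values shown sits.

A single pair cannot show whether other groups at this place would behave the same way, such as a plain hexyl chain, a chain ending in a free carboxylic acid, or one ending in a primary amine. The compounds shown also leave open what the primary carboxamide of compound 1 and compound 3 contributes on its own, since no pair isolates its exchange for a methyl ester.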